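The source may report more compounds than this note shows. Statements on the series, on what has been measured and on what is new or still open speak of the compounds shown alone.

Of the compounds shown here, three have so far been measured in a functional assay on SW-620 cells (Homo sapiens) for antiproliferative activity, read by MTT assay, with a stated time of 72 h; on this read-out lower numbers stand for stronger inhibition and higher numbers for weaker inhibition. Compound 1 `C[Si](C)(C)CCOCn1c(CC(O)(COCc2ccccc2)COCc2ccccc2)cc(=O)[nH]c1=O` reaches only the limit of the assay, giving > 100000 nM in this assay. Compound 2 `O=c1cc(CC(COCc2ccccc2)COCc2ccccc2)[nH]c(=O)[nH]1` likewise sits at the limit, with > 100000 nM in this assay. Compound 3 `O=c1cc(CC(O)COCc2ccccc2)[nH]c(=O)[nH]1` also returns the limit, > 100000 nM in this assay. The step that the two limits leave unreadable from compound 2 to compound 3 therefore cannot be read in size or direction. Going by the values given here, compound 3 thus stands at the limit, exactly where both other measured compounds stand, and this is the single piece of evidence available: the limit of > 100000 nM in this assay, at which 3 of the 3 values shown sit. Compound 4 `C[Si](C)(C)CCOCn1c(CC(O)COCc2ccccc2)cc(=O)[nH]c1=O` differs from compound 3 by a group of 8 heavy atoms (6 carbon, 1 oxygen, 1 silicon; no ring) in place of a hydrogen atom, on an aromatic nitrogen. Among the compounds with values here, no measured step covers this change on its own, and the only compound already carrying the same group, compound 1, also sits at the limit. Compound 4 is therefore expected to behave the same way, with an estimated step that the limit leaves unreadable from compound 3 to compound 4 that does not go beyond the usual scatter. The estimate for compound 4 in this assay is 150000 nM, within a range from 50000 nM to 500000 nM.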

Compound 4, half-maximal inhibitory concentration: > 100000 nM
Compound 4 was reported as a limit (the forecaster's own chance of this, stated with the estimate: 90%); the middle value does not contradict the limit.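

Compound 4, like compound 1 and compound 3, is reported only as a limit and not as a number, so the steps linking compound 4 to them cannot be read. The compounds shown leave open whether any structural change gives a measurable value, as all share one result: the limit of > 100000 nM in this assay, at which 4 of the 4 values shown sit.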